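The source may report more compounds than this note shows. Statements on the series, on what has been measured and on what is new or still open speak of the compounds shown alone.

Three compounds have so far been measured in an ADME assay on Vero cells (Chlorocebus sabaeus) for cytotoxicity, read by fluorescence and resazurin assay, with a stated time of 72 h; a higher number here means that more compound is tolerated, a lower number that less compound is tolerated:

Compound 1, `CC1=CSC2=NC(/C=C/c3ccc(Cl)cc3)=C(C(=O)/C=C/c3ccc(Cl)cc3)C(c3ccccc3)N12`, gives 252 ug/mL.
Compound 2, `CC1=CSC2=NC(/C=C/c3ccc(F)cc3)=C(C(=O)/C=C/c3ccc(F)cc3)C(c3ccccc3)N12`, gives 306 ug/mL.
Compound 3, `COc1ccc(C2C(C(=O)/C=C/c3ccc(Cl)cc3)=C(/C=C/c3ccc(Cl)cc3)N=C3SC=C(C)N32)cc1`, gives 273 ug/mL.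

Compound 1 and compound 3 share a core and differ in one place: methoxy in place of hydrogen on an aromatic carbon. That change gives a 1.1-fold higher number from compound 1 to compound 3 (0.03 log units; within the scatter), so the two values are not distinguished by this assay. Compound 2 stands on a different core; the difference between the core of compound 1 and the core of compound 2 is not broken down here. The values of compound 2 and compound 3 lie within the scatter of each other, as do those of compound 2 and compound 1, so no order among the three can be read from these numbers.

Compound 4, `COc1ccc(C2C(C(=O)/C=C/c3ccc(F)cc3)=C(/C=C/c3ccc(F)cc3)N=C3SC=C(C)N32)cc1`, has not yet been measured. It differs from compound 2 in a single place: methoxy in place of hydrogen on an aromatic carbon. This is the same change that leads from compound 1 to compound 3, made on the other core, and it occurs twice among the four compounds. Because the earlier instance gave a 1.1-fold higher number from compound 1 to compound 3 (0.03 log units; within the scatter), the step from compound 2 to compound 4 in this assay is expected to be small as well, roughly a 1.0-fold higher number from compound 2 to compound 4 (0.02 log units; within the scatter). On that basis compound 4 is estimated at 320 ug/mL, with a range from 200 ug/mL to 480 ug/mL expected to hold most repeat measurements.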

Compound 4, half-maximal cytotoxic concentration: 261 ug/mL
For compound 4 the middle estimate is 1.2-fold (0.09 log units) above the measured one; low and high end bracket the measured number.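

In this assay the same replacement of hydrogen by methoxy on an aromatic carbon, made on the fluorine-bearing core, gives a 1.2-fold lower number from compound 2 to compound 4 (0.07 log units; within the scatter), so this second instance is also too small to separate the two compounds. Set beside the first instance, the step on this core cannot be told apart from the step on the other core: the same change on two cores in this assay, a 1.1-fold higher number (0.03 log units; within the scatter) from compound 1 to compound 3 and a 1.2-fold lower number (0.07 log units; within the scatter) from compound 2 to compound 4, 1.3-fold (0.10 log units) apart, within the scatter of two such steps. This shows that, for these two pairs, the change from phenyl to 4-methoxyphenyl carries from one core to the other as a step that stays within the scatter, but the two steps point in opposite nominal directions, so no direction can be given to the change, and two pairs do not show that it would stay this small on any further core in the series.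

The compounds shown leave open whether a different group at that place, such as an amine, a carboxylic acid or a longer alkoxy chain, would give a step beyond the scatter. They also leave open what a group other than chlorine or fluorine, such as a nitrile or trifluoromethyl, would do at the halogen-bearing positions of these compounds.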